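Lengthening the Alkyl Chain: An Expectation for Compound 4

The compounds below may be only part of what the source reports. "The series", "measured", "known", "first", "only" and "open" are said of these compounds alone.

Compound 2 `CCCCCCc1cc2c(=O)n(CCCSc3nc(-c4cc(OC)c(OC)c(OC)c4)c(C#N)c(=O)[nH]3)cnc2s1` gives the lowest number of the three measured compounds in an ADME assay on PANC-1 cells (Homo sapiens) for inhibition, read by MTT assay (a lower number here means a stronger inhibitor of growth, a higher number a weaker inhibitor of growth), at 28.1 ug/mL. Compound 1 `CCCCCc1cc2c(=O)n(CCCSc3nc(-c4cc(OC)c(OC)c(OC)c4)c(C#N)c(=O)[nH]3)cnc2s1` gives 72.8 ug/mL, and compound 3 `N#Cc1c(-c2ccc(O)cc2)[nH]c(=S)[nH]c1=O` gives 89.1 ug/mL. Compound 4 `CCCCCCCc1cc2c(=O)n(CCCSc3nc(-c4cc(OC)c(OC)c(OC)c4)c(C#N)c(=O)[nH]3)cnc2s1` differs from compound 2 by methyl in place of hydrogen on a saturated chain carbon, six bonds along the chain from an aromatic carbon. Among the measured compounds shown here, only one measured step bears on this change: a 2.6-fold lower number from compound 1 to compound 2 (0.41 log units; beyond the scatter), which is the same kind of chain extension made at the carbon five bonds along the chain. A further lowering of the number is therefore expected for compound 4, likely of similar or somewhat smaller size, as a 1.9-fold lower number from compound 2 to compound 4 (0.27 log units; within the scatter). Compound 4 is estimated at 15 ug/mL in this assay, with a range from 7 ug/mL to 35 ug/mL.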

Compound 4, concentration for 50% growth inhibition: > 100 ug/mL
Compound 4 gave a limit, no number; the forecaster's own chance of this, stated with the estimate: 5%; middle value at least 6.6-fold (0.82 log units) away from the limit.
By their numbers in this assay, from the lowest: compound 2; then compounds 1 and 3 (each within the scatter of the next). At a limit, above all of these: compound 4.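

In this assay, methyl at this carbon, six bonds along the chain, turns the direction of the earlier chain extension around, giving an at least 3.5-fold higher number from compound 2 to compound 4 (0.55 log units; beyond the scatter). Compound 4 gives > 100 ug/mL, which is a limit and not a number. The comparison with the shorter chain gives an at least 1.3-fold higher number from compound 1 to compound 4 (0.13 log units; that floor lies within the scatter), so that floor alone does not separate those two compounds.

As far as these compounds go, the true value of compound 4 remains unknown. Also open, from the compounds shown here alone, is how a longer chain, or an amine or a carboxylic acid in place of the added methyl, would read in this assay.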